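Swapping a dichlorophenyl ring for a methylpyridine

The source may hold more compounds than are shown below. What is called first, only, known or untested is meant among the compounds shown, and "the series" means these compounds.

In a physicochemical assay for solubility, with a stated time of 24 h, at pH 2.2 (a higher number here means a more soluble compound, a lower number a less soluble compound), compound 1 `O=C(NC[C@@H]1[C@H]2CN(C(=O)OCc3cc(Cl)cc(Cl)c3)C[C@@H]12)c1ccc2[nH]c(=O)oc2c1` gives < 1 ug/mL, which is a limit and not a number. Compound 2 `O=C(NC[C@@H]1[C@H]2CN(C(=O)/C=C/c3cc(Cl)cc(Cl)c3)C[C@@H]12)c1ccc2[nH]c(=O)oc2c1` gives < 1 ug/mL, also a limit. Compound 3 `O=C(NC[C@@H]1[C@H]2CN(C(=O)N3CCc4c(Cl)cc(Cl)cc4C3)C[C@@H]12)c1ccc2[nH]c(=O)oc2c1` gives < 1 ug/mL, again a limit. The measurements so far amount to the limit of < 1 ug/mL in this assay, at which 3 of the 3 values shown sit.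

Compound 4 `Cc1ccc(COC(=O)N2C[C@@H]3[C@@H](CNC(=O)c4ccc5[nH]c(=O)oc5c4)[C@@H]3C2)nc1` has 5-methylpyridin-2-yl in place of 3,5-dichlorophenyl on a saturated chain carbon bound to an oxygen next to a carbonyl group. Within the data shown here, no measured compound shows this change. Among the measured compounds shown here, the one measured step, a step that the two limits leave unreadable from compound 1 to compound 2, offers no size to borrow. An upward step is still expected, an at least 30-fold higher number from compound 1 to compound 4 (1.47 log units; beyond the scatter), though its size is only a rough estimate. Compound 4 is estimated at 30 ug/mL, with an expected range of 3 ug/mL to 200 ug/mL.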

Compound 4, solubility: > 92 ug/mL
Compound 4 ended at the assay's limit (the forecaster's own chance of this, stated with the estimate: 15%); middle value at least 3.0-fold (0.48 log units) from the limit.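

The earlier compounds shown here all sat at one limit, so no step could be read among them: the limit of < 1 ug/mL in this assay, at which 3 of the 4 values shown sit. Here, on a saturated chain carbon bound to an oxygen next to a carbonyl group, the ring swap gives an at least 92-fold higher number from compound 1 to compound 4 (1.96 log units; beyond the scatter) in this assay, and the comparison with the ethenyl-linked compound gives an at least 92-fold higher number from compound 2 to compound 4 (1.96 log units; beyond the scatter). Compound 4 sits at the opposite limit, so both sizes are limits and not numbers: the limit of > 92 ug/mL in this assay, at which 1 of the 4 values shown sits.

The compounds shown do not separate the ring nitrogen from the methyl or the loss of the two chlorines. Going by these compounds, how an unsubstituted phenyl or a plain pyridin-2-yl would read here stays open.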